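Swapping hydroxy for amino on a chlorinated quinazoline core

This account rests on a few compounds, and the source may have more. Where it says the series, first, only, none or still open, it means among the compounds named here.

Of the compounds shown here, three have been measured in an assay for inhibition of Dihydrofolate reductase (Homo sapiens); on this read-out higher numbers stand for higher potency (the scale is a negative logarithm) and lower numbers for lower potency. Compound 1, `Nc1nc(O)c2c(Cl)cccc2n1`, gives 4.66 in this assay. Compound 2, `CC(C(=O)Nc1ccc2nc(N)nc(N)c2c1Cl)c1ccccc1`, gives 7.77, and compound 3, `Nc1nc(S)nc2ccccc12`, gives 3.72. Compound 1 therefore stands second highest of the three: compound 3 sits below it, beyond the scatter, while compound 2 sits above it, also beyond the scatter.

Compound 4, `Nc1nc(N)c2c(Cl)cccc2n1`, has not yet been measured. It differs from compound 1 in one place: amino in place of hydroxy on an aromatic carbon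

Among the measured compounds shown here, no step between measured compounds follows this exact change, so any expectation rests on what the three values show. Compound 2, whose core also bears amino rather than hydroxy, though with a further large substituent, gives 7.77, far above compound 1. I expect the change from compound 1 to compound 4 to raise potency in this assay by a step well beyond the scatter, estimated as a number 2.04 log units higher from compound 1 to compound 4 (beyond the scatter). For compound 4 I therefore estimate a value of 6.7 in this assay, most likely between 5.8 and 7.6.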

Compound 4, logarithm of the reciprocal of the active concentration, log(1/C): 6.25
Compound 4: the middle estimate sits 0.45 log units above what was measured; the measured number falls inside the stated range.
By their numbers in this assay, from the lowest: compound 3; then compound 1; then compound 4; then compound 2.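

Among the compounds shown here, with the rest of compound 1 unchanged, amino in place of hydroxy gives a number 1.59 log units higher from compound 1 to compound 4 (beyond the scatter) in this assay, the first direct reading of this change at this position, on an aromatic carbon next to the ring nitrogen. Swapping this single heavy atom is enough to produce a large step, even though the computed comparison gives both groups the same count of hydrogen-bond donors and acceptors and no net charge, so those counts do not separate compound 1 from compound 4. Nothing measured here explains why the amino compound stands higher in this assay.

The compounds shown leave open how other groups at this position would compare, for example a methylamino group or a methoxy group, each of which would show whether the higher number is particular to amino. Also open, from the compounds shown here alone, is whether the same change would give a step of similar size on a core without the chlorine, or on one carrying the larger side chain seen in compound 2.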